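Chain change from compound 1 to compound 3

The source may report more compounds than this note shows. Statements on the series, on what has been measured and on what is new or still open speak of the compounds shown alone.

Within the data shown here, in a functional assay on MCF7 cells (Homo sapiens) for antiproliferative activity, read by CCK-8 assay, with a stated time of 72 h (on this read-out higher numbers stand for weaker inhibition and lower numbers for stronger inhibition), compound 1 `CCOc1cc(C(C)(C)C)ccc1C1=NC(c2ccc(Cl)cc2)C(c2ccc(Cl)cc2)N1C(=O)NCCCCCCCC(=O)Nc1ccccc1N` gives 20300 nM as the higher of the two numbers so far. Compound 2 `CCOc1cc(C(C)(C)C)ccc1C1=NC(c2ccc(Cl)cc2)C(c2ccc(Cl)cc2)N1C(=O)N1CCN(CCCCCCCC(=O)NO)CC1` gives 4830 nM and stands lower. Compound 3 `CCOc1cc(C(C)(C)C)ccc1C1=NC(c2ccc(Cl)cc2)C(c2ccc(Cl)cc2)N1C(=O)NCCCCCC(=O)Nc1ccccc1N` differs from compound 1 by (2-aminophenyl)carbamoyl in place of 2-((2-aminophenyl)carbamoyl)ethyl on a saturated chain carbon, five bonds along the chain from an amide-type nitrogen with (2-aminophenyl)carbamoyl in place of 2-((2-aminophenyl)carbamoyl)ethyl on a saturated chain carbon, five bonds along the chain from an amide-type nitrogen. Among the measured compounds shown here, no measured pair shows this change. The expected step in this assay is a 1.3-fold lower number from compound 1 to compound 3 (0.10 log units; within the scatter) and stays within the scatter. For compound 3 the estimate is 16000 nM with an expected range from 6000 nM to 40000 nM on this read-out.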

Compound 3, half-maximal inhibitory concentration: > 100000 nM
Compound 3: only a limit was reported; the forecaster's own chance of this, stated with the estimate: 10%; middle value at least 6.2-fold (0.79 log units) away from the limit.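

Replacing 2-((2-aminophenyl)carbamoyl)ethyl with (2-aminophenyl)carbamoyl on this saturated chain carbon is not a silent change in this assay: the step is an at least 4.9-fold higher number from compound 1 to compound 3 (0.69 log units; beyond the scatter). Compound 3 carries a limit, not a number: the limit of > 100000 nM in this assay, at which 1 of the 3 values shown sits. Among these compounds, compound 2 differs from compound 1 in more than one place, so this is the first reading of chain length alone, and the shorter chain goes with the weaker inhibition.

On these data alone, whether a longer chain would lower the number on compound 1 stays open. So does whether a carboxylic acid at this place would be tolerated on the shorter or the longer chain.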